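Trifluoromethyl gives way to 4-methyl-1H-imidazol-1-yl

The source may report more compounds than this note shows. Statements on the series, on what has been measured and on what is new or still open speak of the compounds shown alone.

Values measured in an ADME assay on L132 cells (Homo sapiens) for inhibition, read by MTT assay, with a stated time of 72 h (on this read-out higher numbers stand for weaker inhibition of growth and lower numbers for stronger inhibition of growth), are as follows.
- compound 1 `Nc1n[nH]c2cccc(C#Cc3cccc(NC(=O)c4cc(F)cc(C(F)(F)F)c4)c3)c12` gives > 100000 nM as a limit
- compound 2 `Nc1n[nH]c2cccc(C#Cc3cccc(C(=O)Nc4cccc(C(F)(F)F)c4)c3)c12` gives 15300 nM
- compound 3 `Nc1n[nH]c2cccc(C#Cc3cccc(C(=O)Nc4cc(C(F)(F)F)cc(C(F)(F)F)c4)c3)c12` gives > 100000 nM as a limit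

In this assay compound 3 has only the limit > 100000 nM and no exact number. This places compound 3 at the limit of > 100000 nM in this assay, at which 2 of the 3 values shown sit, and so offers a limit as the starting point.

Compound 4 `Cc1cn(-c2cc(NC(=O)c3cccc(C#Cc4cccc5[nH]nc(N)c45)c3)cc(C(F)(F)F)c2)cn1` has not yet been measured. It carries 4-methyl-1H-imidazol-1-yl in place of trifluoromethyl on an aromatic carbon and is otherwise the same as compound 3.

Among the compounds with values here, one measured step bears on this change. It is an at least 6.5-fold higher number from compound 2 to compound 3 (0.81 log units; beyond the scatter) and it came with trifluoromethyl in place of hydrogen on an aromatic carbon. Compound 4 gives up that trifluoromethyl, but it gains a group not seen in the other compounds, so the step can guide the estimate only loosely. Compound 2 lacks that group and, at 15300 nM in the same test, provides the nearest exact number. A lower number, meaning stronger inhibition of growth, is therefore expected. The expected size is an at least 3.3-fold lower number from compound 3 to compound 4 (0.52 log units; beyond the scatter) and another result at the limit remains possible. The estimate for compound 4 is 30000 nM and the expected range runs from 6000 nM to 100000 nM on this reasoning.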

Compound 4, concentration for 50% growth inhibition: 12900 nM
For compound 4 the middle estimate is 2.3-fold (0.37 log units) above the measured one; low and high end bracket the measured number.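

In this assay, within the data shown here, the earlier compounds showed only that a trifluoromethyl group at this place on the ring raised the number; now 4-methyl-1H-imidazol-1-yl at the same place gives an at least 7.7-fold lower number from compound 3 to compound 4 (0.88 log units; beyond the scatter), so the high number of compound 3 belongs to that particular group and not to any substituent here. Set against compound 2, which has only hydrogen at this place, the new group gives a 1.2-fold lower number from compound 2 to compound 4 (0.07 log units; within the scatter), so the two compounds cannot be told apart, and a whole aromatic ring can stand here without any clear shift from the hydrogen compound. The true size of the step from compound 3 remains unknown, because compound 3 has only a limit and no exact number: the limit of > 100000 nM in this assay, at which 2 of the 4 values shown sit.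

As far as these compounds go, with just hydrogen, trifluoromethyl and 4-methyl-1H-imidazol-1-yl compared at this place, it stays open whether the ring itself, its methyl or its hydrogen-bond acceptors account for the result, or simply the loss of the second trifluoromethyl. An imidazole without the methyl, a dimethylamino group or a carboxylic acid at the same place would help separate these possibilities.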